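A few compounds are considered here, and "the series" means these few. Any claim that something is new, unique, unknown or untested is made for them only; others in the source may bear on it.

Measured compounds:
compound 1, `CCOC(=O)c1sc(-c2cccc(NC(=O)c3ccc(Cl)cc3)c2)nc1Nc1ccc(N2CCN(C)CC2)cc1`: 24.3%
compound 2, `CN1CCN(c2ccc(Nc3nc(-c4cccc(NC(=O)c5cccc(F)c5)c4)sc3C(N)=O)cc2)CC1`: 2.78%

Both were tested in a functional assay on Raji cells (Homo sapiens) for antiproliferative activity, read by CCK-8 assay, with a stated time of 72 h, tested at 40 uM; a lower number here means less inhibition, a higher number more inhibition at the concentration tested (going by the name of the read-out). Compound 1 gives 24.3% and compound 2 gives 2.78% in this assay, so compound 2 stands lowest of the two numbers, with compound 1 sitting higher by more than the usual scatter. Within the data shown here, the two differ in two places at once, so no single step between them can be read.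

Compound 3, `CN1CCN(c2ccc(Nc3nc(-c4cccc(NC(=O)c5ccc(Cl)cc5)c4)sc3C(N)=O)cc2)CC1`, has not yet been measured. It differs from compound 2 in one place: 4-chlorophenyl in place of 3-fluorophenyl on a carbonyl carbon. Compound 1 also carries the 4-chlorophenyl group, though on a different core, and its value in this assay is higher than that of compound 2. On that basis a modest rise from compound 2 to compound 3 is expected, a number 7.2 percentage points higher from compound 2 to compound 3 (within the scatter), although a step no larger than the scatter would not surprise. Compound 3 is therefore estimated at 10%, within a range of -2% to 28%.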

Compound 3, a percentage reported as inhibition, at one concentration (the size of the read-out at that concentration, not a potency): 92.6%
Compound 3: the middle estimate sits 82.6 percentage points below what was measured, and the stated range ends below it.
By their numbers in this assay, from the lowest: compound 2; then compound 1; then compound 3.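

In this assay, 4-chlorophenyl in place of 3-fluorophenyl on a carbonyl carbon gives a number 89.8 percentage points higher from compound 2 to compound 3 (beyond the scatter), so the activity of this series depends strongly on which of these two groups sits at this position, even though their heavy-atom and hydrogen-bond counts match. With 4-chlorophenyl held constant, amino in place of ethoxy on a different carbonyl carbon gives a number 68.3 percentage points higher from compound 1 to compound 3 (beyond the scatter), showing that this second site also matters. Nothing measured here gives a reason for either step.

The step from compound 2 to compound 3 changes both the halogen and where it sits on the ring, so 3-chlorophenyl or 4-fluorophenyl would be needed to tell these two changes apart. On these data alone, whether 4-methoxyphenyl at the first site, or a methylamino group or hydroxyl group in place of amino at the second, would keep this level of inhibition remains open.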